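Chloro to Fluoro Swap in a Benzamide Series

A few compounds are considered here, and "the series" means these few. Any claim that something is new, unique, unknown or untested is made for them only; others in the source may bear on it.

Compound 1 `Nc1ccccc1NC(=O)c1ccc(NC(=S)NCc2cccc(F)c2)cc1` and compound 2 `Nc1ccccc1NC(=O)c1ccc(NC(=S)NCc2cccc(Cl)c2)cc1` share a core and differ only in the halogen. In a functional assay on HepG2 cells (Homo sapiens) for cytotoxicity, read by MTT assay, with a stated time of 72 h (on this read-out higher numbers stand for weaker inhibition and lower numbers for stronger inhibition), compound 1 gives 2900 nM, while compound 2 gives 2600 nM. The change fluoro in place of chloro on an aromatic carbon made a step of a 1.1-fold higher number from compound 2 to compound 1 (0.05 log units; within the scatter). Compound 3 `Nc1ccccc1NC(=O)c1ccc(NC(=O)NCc2ccc(Cl)nc2)cc1` carries a different core; the difference between the cores of compound 2 and compound 3 is not broken down here. In this assay compound 3 gives 2400 nM; this value and those of compound 1 and compound 2 lie within the scatter of one another, so no order among the three can be drawn. Compound 4 `Nc1ccccc1NC(=O)c1ccc(NC(=O)NCc2ccc(F)nc2)cc1` has not yet been measured. It differs from compound 3 by fluoro in place of chloro on an aromatic carbon. This is the same kind of change as from compound 2 to compound 1, though the place differs: there the fluoro sits on an aromatic carbon of a six-membered aromatic ring of carbon only, meta to a large group, whereas here it sits on a six-membered aromatic ring with 1 nitrogen, next to the ring nitrogen, para to a large group. The earlier swap gave a 1.1-fold higher number from compound 2 to compound 1 (0.05 log units; within the scatter). On that single precedent, compound 4 is expected to show a step of a 1.1-fold higher number from compound 3 to compound 4 (0.03 log units; within the scatter) in this assay. Compound 4 is thus estimated at 2600 nM, with a range from 1500 nM to 4500 nM.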

Compound 4, half-maximal inhibitory concentration: 13000 nM
Beside the measured number, compound 4's estimate is 5.0-fold (0.70 log units) below it; measured number above the stated range.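

On the core of compound 3, 6-fluoropyridin-3-yl in place of 6-chloropyridin-3-yl gave a 5.4-fold higher number from compound 3 to compound 4 (0.73 log units; beyond the scatter) in this assay, and this step does not match the one seen on the earlier pair: the same change on two cores in this assay, a 1.1-fold higher number (0.05 log units; within the scatter) from compound 2 to compound 1 and a 5.4-fold higher number (0.73 log units; beyond the scatter) from compound 3 to compound 4, 4.9-fold (0.69 log units) apart, beyond the scatter of two such steps. The result shows that, in these two pairs, the size of this swap did not carry over from one core to the other, so the earlier step cannot serve as a general value for the series. It does not show what sets the two steps apart, as the pairs differ both in the core and in the ring that bears the halogen, and two pairs give no rule for other cores.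

The compounds shown leave open how a methyl, a methoxy or an amino group would behave in place of the chloro on the ring with 1 nitrogen. They also leave open whether the same swap on that ring would give a similar step with a thiourea link in place of the urea.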